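Acetylating the Side-Chain Hydroxyl of Compound 1

The source may hold more compounds than are shown below. What is called first, only, known or untested is meant among the compounds shown, and "the series" means these compounds.

The measured compounds:
compound 1, `CC(C)=CC[C@@H](OC[C@@H](C)O)C1=CC(=O)c2c(O)ccc(O)c2C1=O`: 14300 nM
compound 2, `CCCCC(O)CC(=O)O[C@H](CC=C(C)C)C1=CC(=O)c2c(O)ccc(O)c2C1=O`: 45300 nM
compound 3, `CC(C)=CC[C@@H](OC(=O)CC(O)c1ccccc1)C1=CC(=O)c2c(O)ccc(O)c2C1=O`: 17000 nM

In a functional assay on DU-145 cells (Homo sapiens) for cytotoxicity, read by MTT assay (on this read-out higher numbers stand for weaker inhibition and lower numbers for stronger inhibition), compound 1 holds the lowest of the three numbers. Compound 3 lies within the scatter of it, so no order between those two can be claimed, whereas compound 2 lies beyond it. Compound 4 `CC(=O)OC(C)CO[C@H](CC=C(C)C)C1=CC(=O)c2c(O)ccc(O)c2C1=O` keeps the shared core and the ether side chain of compound 1 and differs by 1-acetoxyethyl in place of 1-hydroxyethyl on a saturated chain carbon bound to an oxygen on a saturated carbon.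

For the measured compounds named here, only two measured steps exist, and neither matches this change closely. The step of a 3.2-fold higher number from compound 1 to compound 2 (0.50 log units; beyond the scatter) swaps the whole ether side chain for an ester bearing a hydroxyl and was modest. The step of a 2.7-fold lower number from compound 2 to compound 3 (0.43 log units; beyond the scatter) exchanges butyl for phenyl within that ester series and was also modest. Going by the values given here, both show that changes at the end of the side chain move the numbers only modestly, and no step shows what capping the hydroxyl as an acetate does. The account therefore expects a step of a 1.3-fold higher number from compound 1 to compound 4 (0.10 log units; within the scatter) of no more than modest size, most likely within the scatter, with a slight lean toward a higher number. Compound 4 is estimated at 18000 nM, within a range of 7000 nM to 45000 nM.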

Compound 4, half-maximal inhibitory concentration: 16600 nM
Compound 4: middle estimate off by 1.1-fold (0.04 log units), on the high side; the measured number falls inside the stated range.
By their numbers in this assay, from the lowest: compounds 1, 4 and 3 (each within the scatter of the next); then compound 2.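

In this assay, for the compounds shown here, the change to 1-acetoxyethyl gives a 1.2-fold higher number from compound 1 to compound 4 (0.06 log units; within the scatter), showing that at this place the side chain tolerates the loss of the hydrogen-bond donor of 1-hydroxyethyl, which the earlier steps could not show. The step of a 2.7-fold lower number from compound 2 to compound 4 (0.44 log units; beyond the scatter) shows that compound 4, like compound 1, differs from the hydroxylated ester side chain of compound 2 by more than the scatter. No available evidence explains either step.

The compounds shown leave open whether a larger ester such as benzoyloxy, or an amine or a carboxylic acid in place of the hydroxyl, would also leave the number within the scatter of compound 1. They also leave open whether the defined stereocentre of 1-hydroxyethyl, absent from the 1-acetoxyethyl of compound 4, matters here.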